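A few compounds are considered here, and "the series" means these few. Any claim that something is new, unique, unknown or untested is made for them only; others in the source may bear on it.

Measured in a functional assay on MCF7 cells (Homo sapiens) for antiproliferative activity, read by MTT assay; a lower number here means a stronger inhibitor, a higher number a weaker inhibitor:
- compound 1 `COc1ccc([C@@H]2C(Cc3cccs3)C(=O)N2c2cc(OC)c(OC)c(OC)c2)cc1`: 1640 nM
- compound 2 `COc1ccc([C@@H]2[C@@H](C(=O)c3cccs3)C(=O)N2c2cc(OC)c(OC)c(OC)c2)cc1`: 950 nM
- compound 3 `COc1cc(N2C(=O)[C@H](c3cccs3)[C@H]2c2cccc3ccccc23)cc(OC)c1OC`: 620 nM

Compound 1 lies within the usual scatter of compound 2, so these two cannot be told apart. Compound 3 shows a lower number than compound 1, and that gap lies beyond the scatter.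

The next compound is compound 4 `COc1ccc([C@@H]2C(c3ccc(C)s3)C(=O)N2c2cc(OC)c(OC)c(OC)c2)cc1`. It differs from compound 1 in one place: 5-methylthiophen-2-yl stands in place of (thiophen-2-yl)methyl on a saturated ring carbon (5-methylthiophen-2-yl in place of (thiophen-2-yl)methyl on a saturated ring carbon).

Within the data shown here, no measured pair shows this change on its own, so the expectation rests on thin evidence. The closest guide is compound 3, which also carries its thiophene straight on that ring carbon and gives 620 nM, although its other groups differ from those of compound 1. A moderate move towards a lower number therefore seems likely, and the expected step is a 3.6-fold lower number from compound 1 to compound 4 (0.56 log units; beyond the scatter).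

For compound 4 the estimated value is 450 nM, with an expected range from 110 nM to 1800 nM.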

Compound 4, half-maximal inhibitory concentration: 250 nM
Beside the measured number, compound 4's estimate is 1.8-fold (0.26 log units) above it; the range from low to high includes it.
By their numbers in this assay, from the lowest: compound 4; then compounds 3, 2 and 1 (each within the scatter of the next, the first and the last beyond it).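

On this saturated ring carbon of the four-membered ring, putting 5-methylthiophen-2-yl in place of (thiophen-2-yl)methyl gives a 6.6-fold lower number from compound 1 to compound 4 (0.82 log units; beyond the scatter) in this assay. The two groups have the same atoms, joined differently, and the same counts of hydrogen-bond donors and acceptors, so this position clearly tells apart two arrangements of one set of atoms. Nothing measured here accounts for the size of this step.

The step combines two alterations, the thiophene coming to sit directly on the ring carbon and a methyl appearing on the thiophene, and the compounds shown do not separate their contributions. From the compounds shown here alone, it also stays open whether an ethyl group or a carboxylic acid in place of that methyl would keep, improve or lose this activity.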